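This account rests on a few compounds, and the source may have more. Where it says the series, first, only, none or still open, it means among the compounds named here.

Working notes on the series.

Compound 1 `Cc1ccc([C@@H](C)Oc2cc3onc(CCC(=O)O)c3cc2Cl)nc1` holds the lowest number of the three measured in an assay on HEK293 cells for inhibition of kynurenine 3-monooxygenase (Homo sapiens), read by LC-MS, with a stated time of 20 h (a higher number here means a weaker inhibitor, a lower number a stronger inhibitor), where compound 1 gives 1.59 nM. Compound 3 `C[C@@H](Oc1cc2oc(=O)n(CCC(=O)O)c2cc1Cl)c1cccnn1` gives 631 nM in this assay, and compound 2 `O=C(O)CCn1c(=O)oc2cc(OCC3CCC3)c(Cl)cc21` gives 1260 nM; both sit on a different core from compound 1, so their gap to compound 1 says little about the change considered here.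

Compound 4 `Cc1ccc([C@@H](C)Oc2cc3onc(CCC(=O)O)c3cc2Cl)nn1` differs from compound 1 in one place: 6-methylpyridazin-3-yl in place of 5-methylpyridin-2-yl on a saturated chain carbon bound to an oxygen on an aromatic ring and a saturated chain carbon. Among the compounds with values here, the only measured step that touches a methylpyridazinyl group is a 2.0-fold lower number from compound 2 to compound 3 (0.30 log units; within the scatter), which swapped it in for a cyclobutylmethyl group on the oxygen of the other core; it moved the number by an amount within the scatter. Within the data shown here, no measured pair shows a methylpyridinyl against a methylpyridazinyl on the same core, so the expectation rests on that single small step and on the parent being very potent.

The expected step from compound 1 to compound 4 is therefore modest, a 2.0-fold higher number from compound 1 to compound 4 (0.30 log units; within the scatter), with a slight loss allowed for. Compound 4 is estimated at 3.2 nM in this assay, with a range of 1 nM to 12 nM.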

Compound 4, half-maximal inhibitory concentration: 3.16 nM
For compound 4 the middle estimate is 1.0-fold (0.01 log units) above the measured one, within the range that was stated.
By their numbers in this assay, from the lowest: compounds 1 and 4 (each within the scatter of the next); then compounds 3 and 2 (each within the scatter of the next).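

Within the data shown here, on the core of compound 1, on a saturated chain carbon bound to an oxygen on an aromatic ring and a saturated chain carbon, 6-methylpyridazin-3-yl in place of 5-methylpyridin-2-yl gives a 2.0-fold higher number from compound 1 to compound 4 (0.30 log units; within the scatter) in this assay, the first direct comparison of these two groups on one core. At this position, the two groups therefore cannot be told apart in this assay. Nothing at hand explains why the two groups read alike.

As far as these compounds go, it remains open whether a methoxy or trifluoromethyl group in place of the ring methyl would leave the number within the scatter. The same exchange on the core of compound 3 is also an open question.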